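This account rests on a few compounds, and the source may have more. Where it says the series, first, only, none or still open, it means among the compounds named here.

Measured so far in an assay on isolated protein for inhibition of Fatty-acid amide hydrolase 1 (Rattus norvegicus), with a stated time of 60 min; on this read-out lower numbers stand for stronger inhibition and higher numbers for weaker inhibition:
compound 1 `O=C(Nc1cccc2nonc12)N1CCN(Cc2cccc(Oc3ccc(Cl)cc3)c2)CC1`: 120 nM
compound 2 `Cc1nc2cc(NC(=O)N3CCN(Cc4cccc(Oc5ccc(Cl)cc5)c4)CC3)ccc2o1`: 200 nM

Compound 2 carries the higher number of the two, yet the step of a 1.7-fold higher number from compound 1 to compound 2 (0.22 log units; within the scatter) lies within the scatter, so nothing separates compound 2 from compound 1. Compound 3 `O=C(Nc1ccn2ccnc2c1)N1CCN(Cc2cccc(Oc3ccc(Cl)cc3)c2)CC1` differs from compound 2 by a group of 9 heavy atoms (7 carbon, 2 nitrogen; one five-membered aromatic ring with 2 hetero atoms, one six-membered aromatic ring with 1 hetero atom) in place of a group of 10 heavy atoms (8 carbon, 1 nitrogen, 1 oxygen; one five-membered aromatic ring with 2 hetero atoms, one six-membered aromatic ring of carbon only), on an amide-type nitrogen. Within the data shown here, the only measured step that bears on this position, a 1.7-fold higher number from compound 1 to compound 2 (0.22 log units; within the scatter), likewise exchanged the whole aryl group on the amide-type nitrogen and stayed within the scatter. For compound 3 in this assay a step of no change at the digits printed from compound 2 to compound 3 (within the scatter) is therefore expected, meaning no change beyond the scatter. Compound 3 is estimated at 200 nM, with a range from 70 nM to 600 nM.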

Compound 3, half-maximal inhibitory concentration: 2600 nM
For compound 3 the middle estimate is 13-fold (1.11 log units) below the measured one; measured number above the stated range.
By their numbers in this assay, from the lowest: compounds 1 and 2 (each within the scatter of the next); then compound 3.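

In this assay, the aryl group on the amide-type nitrogen is not freely exchangeable: a 13-fold higher number from compound 2 to compound 3 (1.11 log units; beyond the scatter) and a 22-fold higher number from compound 1 to compound 3 (1.34 log units; beyond the scatter) are both large, whereas the earlier exchange stayed within the scatter. The two groups with a six-membered aromatic ring of carbon only sit together, and the group with one hetero atom in that ring stands apart. No available evidence explains the loss.

Three groups cannot show whether the ring nitrogen or the whole fused group governs this step. A plain phenyl or a pyridyl group on the same nitrogen would bear on that question.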